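Swapping the Aryl Group on the Ring Amine

This account rests on a few compounds, and the source may have more. Where it says the series, first, only, none or still open, it means among the compounds named here.

Within the data shown here, in a functional assay on CHO cells with adenosine receptor A1 (Homo sapiens) as the target, read by cAMP accumulation and immunoassay, with a stated time of 6 min, tested at 10 uM (a lower number here means a stronger effect, a higher number a weaker effect of the compound at the concentration tested), compound 2 `Nc1scc(CN2CCN(c3ccc(F)c(Cl)c3)CC2)c1C(=O)c1ccc(Cl)cc1` gives -78%, the lower of the two numbers known so far; compound 1 `Nc1scc(CN2CCN(c3ccccc3C(F)(F)F)CC2)c1C(=O)c1ccc(Cl)cc1` gives -60%. Compound 3 `Nc1scc(CN2CCN(c3cc(Cl)ccc3Cl)CC2)c1C(=O)c1ccc(Cl)cc1` has not been measured. It differs from compound 2 by 2,5-dichlorophenyl in place of 3-chloro-4-fluorophenyl on an amine nitrogen in a ring. One measured step changes the group at this same place on the shared core, a number 18 percentage points lower from compound 1 to compound 2 (beyond the scatter), and it was modest, so another new aryl group there may shift the number somewhat in either direction. Near the value of compound 2, compound 3 is estimated at -70%, within -92% to -45%, an expected step of a number 8 percentage points higher from compound 2 to compound 3 (within the scatter).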

Compound 3, a percentage reported as activity, at one concentration (the size of the read-out at that concentration, not a potency): -62%
Compound 3: the middle estimate sits 8 percentage points below what was measured; measured number inside the range.
By their numbers in this assay, from the lowest: compound 2; then compounds 3 and 1 (each within the scatter of the next).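

Within this assay, replacing one aryl group with another of 8 heavy atoms still shifts the result (a number 16 percentage points higher from compound 2 to compound 3 (beyond the scatter)), so the heavy-atom count alone does not set the number at this position. The 2,5-dichlorophenyl and 2-(trifluoromethyl)phenyl groups cannot be told apart (a number 2 percentage points lower from compound 1 to compound 3 (within the scatter)), which leaves compound 2 alone with the lowest number. No measurement available here explains what sets the 3-chloro-4-fluorophenyl group apart. As far as these compounds go, it remains open how an unsubstituted phenyl or a pyridine ring on this nitrogen would compare with compound 2.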